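The source may hold more compounds than are shown below. What is called first, only, known or untested is meant among the compounds shown, and "the series" means these compounds.

Measured so far in a functional assay on MCF7 cells (Homo sapiens) for antiproliferative activity, read by CCK-8 assay, with a stated time of 72 h; on this read-out lower numbers stand for stronger inhibition and higher numbers for weaker inhibition:
compound 1 `O=C(Nc1cccc(-c2oc3cc(-c4ccc(F)cc4)ccc3c(=O)c2O)c1)c1ccc(F)cc1F` gives 13500 nM
compound 2 `CCc1ccc(C(=O)Nc2cccc(-c3oc4cc(-c5ccc(F)cc5)ccc4c(=O)c3O)c2)cc1` gives 22800 nM
compound 3 `Cc1cc(C(=O)Nc2cccc(-c3oc4cc(-c5ccc(F)cc5)ccc4c(=O)c3O)c2)ccc1F` gives 7710 nM

Compound 1 stands second highest of the three numbers. Its nearest neighbour is compound 2, a 1.7-fold higher number from compound 1 to compound 2 (0.23 log units; within the scatter); its furthest is compound 3, a 1.8-fold lower number from compound 1 to compound 3 (0.24 log units; within the scatter); both steps lie within the scatter, so compound 1 is not ordered against either.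

Compound 4 `Cc1cc(C)cc(C(=O)Nc2cccc(-c3oc4cc(-c5ccc(F)cc5)ccc4c(=O)c3O)c2)c1` has not yet been measured in this assay. It differs from compound 1 in one place: 3,5-dimethylphenyl in place of 2,4-difluorophenyl on a carbonyl carbon.

Within the data shown here, the steps that bear on this change are the three in which only the group on the carbonyl carbon is exchanged: a 1.7-fold higher number from compound 1 to compound 2 (0.23 log units; within the scatter), a 1.8-fold lower number from compound 1 to compound 3 (0.24 log units; within the scatter) and a 3.0-fold lower number from compound 2 to compound 3 (0.47 log units; beyond the scatter). Only the last reaches beyond the scatter, and it is modest. Across compounds 1, 2 and 3 this position moves the number little, though three compounds are a thin basis and no wider claim is made.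

For compound 4 a step of no size beyond the scatter is expected, a 1.1-fold higher number from compound 1 to compound 4 (0.05 log units; within the scatter). Compound 4 is estimated at 15000 nM, with a range from 6000 nM to 40000 nM.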

Compound 4, half-maximal inhibitory concentration: 20400 nM
Estimate against measurement, compound 4: 1.4-fold (0.13 log units) below; the measured number falls inside the stated range.
By their numbers in this assay, from the lowest: compounds 3, 1, 4 and 2 (each within the scatter of the next, the first and the last beyond it).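

In this assay the exchange of 2,4-difluorophenyl for the all-carbon 3,5-dimethylphenyl, with the same count of heavy atoms, gives a 1.5-fold higher number from compound 1 to compound 4 (0.18 log units; within the scatter) and the comparison with the 4-ethylphenyl amide gives a 1.1-fold lower number from compound 2 to compound 4 (0.05 log units; within the scatter) so the two fluorines of compound 1 are not shown to matter at this position. A second step beyond the scatter appears, a 2.6-fold higher number from compound 3 to compound 4 (0.42 log units; beyond the scatter) and so both compound 2 and compound 4 stand apart from compound 3 with its 4-fluoro-3-methylphenyl, though compound 1 goes against any wider pattern by staying within the scatter of compound 3. No measurement at hand accounts for these steps.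

From the compounds shown here alone, whether the fluorine or the methyl of compound 3 carries its separation stays open. Also open, going by these compounds, is whether a carboxylic acid, an amine or a longer chain on this phenyl ring would move the number further.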